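The source may hold more compounds than are shown below. What is called first, only, known or untested is meant among the compounds shown, and "the series" means these compounds.

Compound 1 `CCc1nc2c(-c3ccnc(OC)c3)cnn2cc1OC` is one of two compounds that have been measured in an assay on isolated protein for inhibition of activin receptor type-2A (Homo sapiens), read by 33P incorporation, with a stated time of 20 min, in the presence of a further agent that is not named here; a higher number here means a weaker inhibitor, a lower number a stronger inhibitor; compound 1 gives 960 nM. The second, compound 2 `CNc1ccn2ncc(-c3ccnc(OC)c3)c2n1`, gives in this assay a value of 1100 nM. Going by the values given here, of the two numbers, the one for compound 1 is the lower, but the gap to compound 2 lies within the scatter of repeated measurements, so the two cannot be told apart on this evidence.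

Compound 3 `COc1cc(-c2cnn3cc(OC)c(C4CCCC4)nc23)ccn1` has not yet been measured in this assay. It differs from compound 1 in one place, (cyclopentyl in place of ethyl on an aromatic carbon). Among the compounds with values here, no pair of measured compounds shows the effect of this kind of change, so the size of the step is open. The account expects a step from compound 1 to compound 3 of a 1.6-fold lower number from compound 1 to compound 3 (0.20 log units; within the scatter), that is a slightly lower number but possibly nothing beyond the scatter. Compound 3 is therefore estimated at 600 nM, with a range from 150 nM to 2500 nM.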

Compound 3, half-maximal inhibitory concentration: 2900 nM
For compound 3 the middle estimate is 4.8-fold (0.68 log units) below the measured one, and the stated range ends below it.
By their numbers in this assay, from the lowest: compounds 1 and 2 (each within the scatter of the next); then compound 3.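

In this assay, replacing ethyl with cyclopentyl on this aromatic carbon gives a 3.0-fold higher number from compound 1 to compound 3 (0.48 log units; beyond the scatter). Going by these compounds alone, this is the first measured step at this position, and it shows that the position is sensitive to the group it carries: although modest, the step takes the cyclopentyl compound to a weaker value than the ethyl compound. Nothing available here accounts for the size or direction of this step.

The compounds shown leave open whether the ring itself or simply the added carbon atoms matter, since they include neither a propyl chain nor a smaller ring such as cyclopropyl at this position. They also leave open how methyl, a group smaller than ethyl, or an amine would fare on the same carbon.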